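This account rests on a few compounds, and the source may have more. Where it says the series, first, only, none or still open, it means among the compounds named here.

The measured compounds and their values in a functional assay on HCT-116 cells (Homo sapiens) for inhibition, read by sulforhodamine B assay, with a stated time of 72 h; on this read-out lower numbers stand for stronger inhibition and higher numbers for weaker inhibition:

Compound 1, `COc1ccc2cc(C(C)c3nnc4n3N=C(c3ccc(Br)cc3)CS4)ccc2c1`: 11700 nM
Compound 2, `CC(c1ccc(-c2ccccc2)c(F)c1)c1nnc2n1N=C(c1ccc(Cl)cc1Cl)CS2`: 6900 nM
Compound 3, `COc1ccc(C2=Nn3c(nnc3C(C)c3ccc(-c4ccccc4)c(F)c3)SC2)cc1`: 4400 nM

Among these three, compound 3 has the lowest number in this assay. Its gap to compound 2 is within the scatter, so the two cannot be ordered; only its gap to compound 1 lies beyond the scatter, and compound 1 also differs from compound 3 in more than one place.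

Compound 4, `CC(c1ccc(-c2ccccc2)c(F)c1)c1nnc2n1N=C(c1ccc(F)cc1)CS2`, has not yet been measured in this assay. It differs from compound 3 by fluoro in place of methoxy on an aromatic carbon, a fluoro in place of a methoxy on an aromatic carbon, para to a large group; cut one bond further out, the change reads 4-methoxyphenyl to 4-fluorophenyl.

Within the data shown here, no measured step changes this group in the same way. The nearest comparison is a 1.6-fold lower number from compound 2 to compound 3 (0.20 log units; within the scatter), which exchanges the whole aryl group at the same place and stays within the scatter. Among the measured compounds shown here, compound 1 carries a halogen at that position on a different left-hand part and gives a higher number, but no single step links it to compound 3. On that basis a small step is expected for compound 4, a 1.4-fold higher number from compound 3 to compound 4 (0.13 log units; within the scatter), toward a somewhat higher number but not beyond the scatter. Compound 4 is therefore estimated at 6000 nM, within a range from 2500 nM to 15000 nM.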

Compound 4, half-maximal inhibitory concentration: 10500 nM
Beside the measured number, compound 4's estimate is 1.8-fold (0.24 log units) below it; the measured number falls inside the stated range.
By their numbers in this assay, from the lowest: compounds 3, 2, 4 and 1 (each within the scatter of the next, the first and the last beyond it).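

In this assay, among these compounds, fluoro in place of methoxy on this aromatic carbon gives a 2.4-fold higher number from compound 3 to compound 4 (0.38 log units; beyond the scatter), the first change in a single place here whose size lies beyond the scatter, so a group at this position can move the number while the rest of the structure stays the same. The other comparison at the position, a 1.5-fold higher number from compound 2 to compound 4 (0.18 log units; within the scatter), stays within the scatter, as does a 1.6-fold lower number from compound 2 to compound 3 (0.20 log units; within the scatter), so of the three aryl groups only 4-methoxyphenyl and 4-fluorophenyl can be told apart, and 2,4-dichlorophenyl cannot be separated from either one. Nothing in the information available explains why the methoxy and fluoro forms differ.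

The compounds shown leave open how other groups on this aromatic carbon, such as an amine, a hydroxyl or a plain methyl, would compare with methoxy and fluoro. They also leave open whether exchanging methoxy for fluoro gives a step of similar size when the other side of the molecule is changed, for instance to the methoxy-bearing fused aromatic part carried by compound 1.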